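The compounds below may be only part of what the source reports. "The series", "measured", "known", "first", "only" and "open" are said of these compounds alone.

Values from a functional assay on HepG2 cells (Homo sapiens) for cytotoxicity, read by spectrophotometry, with a stated time of 72 h (on this read-out higher numbers stand for weaker inhibition and lower numbers for stronger inhibition), for the series so far
- compound 1 `COc1cc(-n2c(-c3cccc(F)c3)cccc2=O)cc(OC)c1OC` gives 159 nM
- compound 2 `COc1ccc(-n2c(-c3cc(OC)c(OC)c(OC)c3)cccc2=O)cc1OCc1ccccc1` gives 3040 nM
- compound 3 `COc1ccc(-n2c(-c3cc(OC)c(OC)c(OC)c3)cccc2=O)cc1O` gives 1220 nM

Compound 3 at 1220 nM is second highest of the three numbers, with compound 2 at 3040 nM on the higher side and compound 1 at 159 nM on the lower side. The next structure is compound 4 `COc1ccc(-n2c(-c3cc(OC)c(OC)c(OC)c3)cccc2=O)cc1` and its difference from compound 3 is hydrogen in place of hydroxy on an aromatic carbon which in words is hydrogen in place of hydroxy on an aromatic carbon, so that 3-hydroxy-4-methoxyphenyl becomes 4-methoxyphenyl.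

Among the measured compounds shown here, the one measured step that bears on this is a 2.5-fold lower number from compound 2 to compound 3 (0.40 log units; beyond the scatter) and it is modest. That step exchanges the group on the same oxygen that leaves here. For the measured compounds named here, no measured pair removes that oxygen, so the step offers only a rough scale and no direction. Going by the values given here, compound 1 differs from the others in more than one place and sets no step here. In this assay a small change is expected, most likely none beyond the scatter. The estimate means an expected 1.2-fold lower number from compound 3 to compound 4 (0.09 log units; within the scatter) with no firm direction. For compound 4 the estimated value is 1000 nM with an expected range from 300 nM to 3500 nM on this read-out.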

Compound 4, half-maximal inhibitory concentration: 5740 nM
The estimate for compound 4 lay 5.7-fold (0.76 log units) below the measured number; the whole stated range lies below it.
By their numbers in this assay, from the lowest: compound 1; then compound 3; then compounds 2 and 4 (each within the scatter of the next).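

In this assay, among the compounds shown here, removing the hydroxy from the aromatic carbon ortho to a methoxy group gives a 4.7-fold higher number from compound 3 to compound 4 (0.67 log units; beyond the scatter) and is the first measured change in which the oxygen at this carbon leaves altogether. Exchanging benzyloxy for hydrogen at the same carbon gives a 1.9-fold higher number from compound 2 to compound 4 (0.28 log units; within the scatter), so these two substituents are not told apart here, while hydroxy stands apart from both, as a 2.5-fold lower number from compound 2 to compound 3 (0.40 log units; beyond the scatter) also shows. Across these three compounds, the oxygen alone does not set the number, since benzyloxy also carries an oxygen at this carbon yet is not separated from hydrogen, and nothing available explains why the hydroxy compound stands apart.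

Still open, on these data alone, is whether an amine or a carboxylic acid at this carbon would read with hydroxy or with hydrogen and benzyloxy, since only these three substituents are compared at this position. For the compounds shown here, also open is whether the same gap holds on the core of compound 1, which stands at 159 nM but differs from the others in more than one place and so gives no step at this carbon.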